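The source may hold more compounds than are shown below. What is called first, only, known or untested is meant among the compounds shown, and "the series" means these compounds.

Measured compounds:
- compound 1, `CC(C)c1ccc2c(CCCCNS(=O)(=O)c3ccccc3)cc(C(=O)O)c-2cc1` — > 100000 nM in this assay
- compound 2, `CC(C)c1ccc2c(CCCCNS(=O)(=O)c3ccc(Cl)cc3)cc(C(=O)O)c-2cc1` — > 100000 nM in this assay

In a functional assay (plasma) for inhibition, with Oryctolagus cuniculus as the target (on this read-out lower numbers stand for stronger inhibition and higher numbers for weaker inhibition), compound 1 gives > 100000 nM, and this is a limit of the assay rather than a number. Compound 2 also gives > 100000 nM, again a limit of the assay. The step that the two limits leave unreadable from compound 1 to compound 2 is therefore not readable in size, since both ends rest on (the limit of > 100000 nM in this assay, at which 2 of the 2 values shown sit). Compound 1 thus stands at the limit of the assay, and nothing among the shown values tells how far beyond it the true number lies.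

Compound 3, `CC(C)c1ccc2c(/C=C/C(=O)O)cc(CCCCNS(=O)(=O)c3ccccc3)c-2cc1`, is the unmeasured compound. It differs from compound 1 by 2-carboxyethenyl in place of carboxy on an aromatic carbon. Among the compounds with values here, no measured step bears on this change: the only measured step, from compound 1 to compound 2, is a chloro in place of hydrogen and is unreadable in any case. No direction or size can be anticipated from the measured data beyond the scatter.

The estimate for compound 3 in this assay is 80000 nM, with a range from 8000 nM to 300000 nM. The step this estimate implies, an at least 1.2-fold lower number from compound 1 to compound 3 (0.09 log units; that floor lies within the scatter), is expected only as a guess that compound 3 may stay near the limit.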

Compound 3, half-maximal inhibitory concentration: > 100000 nM
Compound 3 gave a limit, no number; the forecaster's own chance of this, stated with the estimate: 55%; at least 1.2-fold (0.09 log units) between middle value and limit.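

In this assay compound 3 gives > 100000 nM, which is a limit and not a number. The step from compound 1 to compound 3 therefore cannot be read, because both values rest on a limit: the limit of > 100000 nM in this assay, at which 3 of the 3 values shown sit.

The compounds shown leave open how far beyond the limit each true value lies, and whether 2-carboxyethenyl in place of carboxy changes inhibition at all.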